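The source may hold more compounds than are shown below. What is called first, only, known or untested is meant among the compounds shown, and "the series" means these compounds.

For the measured compounds named here, compound 1 `COc1cc(OC)c(C(=O)/C=C/c2ccccc2)c(OC)c1` is the only compound here that comes with a number: in a functional assay on MDA-MB-231 cells (Homo sapiens), read by fluorescence and BrdU incorporation, with a stated time of 48 h, tested at 10 uM (on this read-out lower numbers stand for a stronger effect and higher numbers for a weaker effect at the one concentration tested), compound 1 gives 37%. Compound 2 `COc1cc(O)c(C(=O)/C=C/c2ccccc2OC)c(OC)c1` was reported in this assay as "not active" (no number reported), with no number attached. Compound 3 `COc1cc(OC)c(C(=O)/C=C/c2ccc(Br)cc2)c(OC)c1` differs from compound 1 by bromo in place of hydrogen on an aromatic carbon, which one bond further out reads as phenyl to 4-bromophenyl. Going by the values given here, no step between two measured compounds is available to anchor this change, so the expectation rests on compound 1 alone. In this assay the expected step is a number 5 percentage points lower from compound 1 to compound 3 (within the scatter), a modest shift toward a stronger effect that may not exceed the usual scatter. Compound 3 is therefore estimated at 32%, within a range from 12% to 58%.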

Compound 3, a percentage reported as activity, at one concentration (the size of the read-out at that concentration, not a potency): 42%
Estimate against measurement, compound 3: 10 percentage points below, within the range that was stated.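

In this assay bromo in place of hydrogen on the aromatic carbon gives a number 5 percentage points higher from compound 1 to compound 3 (within the scatter) so compound 1 and compound 3 cannot be told apart here. This is the first pair shown that differs in one place, and it shows that this position can carry a bromine atom without a difference that stands clear of the scatter. Nothing shown offers an explanation for this result. Going by these compounds, whether an amine, a carboxylic acid or a longer chain at the same position would read differently remains open.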